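Compound 4 and the limit of the HepG2 assay

The compounds below may be only part of what the source reports. "The series", "measured", "known", "first", "only" and "open" are said of these compounds alone.

Measured in a functional assay on HepG2 cells (Homo sapiens), read by MTT assay, with a stated time of 48 h; on this read-out lower numbers stand for stronger inhibition and higher numbers for weaker inhibition:
Compound 1 `CCn1c(C(=O)N(C)CCC#N)ccc1C(CC)(CC)c1ccc(OCC(O)C(C)(C)C)c(C)c1`: > 50000 nM (a limit)
Compound 2 `CCn1c(C(=O)N(CCC#N)CCC#N)ccc1C(CC)(CC)c1ccc(OCC(O)C(C)(C)C)c(C)c1`: 42000 nM
Compound 3 `C#CC(C)OC(=O)c1ccc(C(CC)(CC)c2ccc(OCC(O)C(C)(C)C)c(C)c2)n1CC`: > 50000 nM (a limit)

Compound 3 gives only a limit in this assay, namely > 50000 nM, and not a number. It shares this position with compound 1, as the limit of > 50000 nM in this assay, at which 2 of the 3 values shown sit, shows. Compound 2 is the only one of the three with a measured number, 42000 nM.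

The next compound is compound 4 `CCn1c(C(=O)N(C)CC(=O)O)ccc1C(CC)(CC)c1ccc(OCC(O)C(C)(C)C)c(C)c1`. The change leading to it is (carboxymethyl)(methyl)amino in place of (1-methylprop-2-yn-1-yl)oxy on a carbonyl carbon. In words, (carboxymethyl)(methyl)amino stands in place of (1-methylprop-2-yn-1-yl)oxy on a carbonyl carbon.

Two measured steps involve a change at this same carbonyl carbon: a step that the two limits leave unreadable from compound 1 to compound 3 and an at least 1.1-fold higher number from compound 2 to compound 3 (0.07 log units; that floor lies within the scatter). A third, an at least 1.1-fold lower number from compound 1 to compound 2 (0.07 log units; that floor lies within the scatter), alters the group on the amide-type nitrogen. None of the three can be read as a step beyond the scatter. Compound 1 also carries a methyl-substituted amino group on this carbonyl carbon, and it gives > 50000 nM, which is a limit.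

These results give no reason to expect a real gain, so no step beyond the scatter is expected. The expected outcome is a number no higher from compound 3 to compound 4 (the limit leaves the size open). For compound 4 the estimated value is 50000 nM, with an expected range from 25000 nM to 100000 nM.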

Compound 4, half-maximal inhibitory concentration: 17100 nM
Compound 4: middle estimate off by 2.9-fold (0.47 log units), on the high side; measured number outside the range, below it.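

In this assay, for the compounds shown here, this is the first change at the carbonyl carbon to give a step that can be read as beyond the scatter: (carboxymethyl)(methyl)amino in place of (1-methylprop-2-yn-1-yl)oxy gives an at least 2.9-fold lower number from compound 3 to compound 4 (0.46 log units; beyond the scatter). The same group, set in place of the larger group of compound 2, gives a 2.5-fold lower number from compound 2 to compound 4 (0.39 log units; beyond the scatter), and carboxy in place of cyanomethyl on a saturated chain carbon bound to an amide-type nitrogen gives an at least 2.9-fold lower number from compound 1 to compound 4 (0.46 log units; beyond the scatter), so a carboxy-bearing group on this carbonyl carbon now stands apart from each earlier compound. Two of these steps start from a limit, which means that their sizes are floors and not measured gaps: the limit of > 50000 nM in this assay, at which 2 of the 4 values shown sit.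

The compounds shown leave open whether the carboxylic acid itself is needed for this step, and a methyl ester or a primary amide in its place would be the direct comparison. They also leave open what a longer chain carrying the carboxy group on the amide-type nitrogen, or an amine in place of the carboxy group, would give.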